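Amide Variation on a Shared Diarylalkyne Core

The source may hold more compounds than are shown below. What is called first, only, known or untested is meant among the compounds shown, and "the series" means these compounds.

Measured so far in a functional assay on TREX cells for negative allosteric modulation of metabotropic glutamate receptor 3 (Rattus norvegicus), read by calcium flux, with a stated time of 2.5 min; on this read-out higher numbers stand for weaker inhibition and lower numbers for stronger inhibition:
- Compound 1 `COc1ccc(C#Cc2ccc(C(=O)N3CCCC(OC)C3)cc2)cc1`: 5500 nM
- Compound 2 `COc1ccc(C#Cc2ccc(C(=O)N3CC[C@@H](O)C3)cc2)cc1`: 10200 nM
- Compound 3 `COc1ccc(C#Cc2ccc(C(=O)N3CC4CCC(O)C4C3)cc2)cc1`: 5500 nM

Compound 3 stands level with compound 1 at the digits shown, and these two give the lowest numbers of the three; compound 2 lies furthest away, though still within the scatter.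

Compound 4 `COc1ccc(C#Cc2ccc(C(=O)NC(C)CO)cc2)cc1` is the next step. Relative to compound 3, the change is a group of 5 heavy atoms (3 carbon, 1 nitrogen, 1 oxygen; no ring) in place of a group of 9 heavy atoms (7 carbon, 1 nitrogen, 1 oxygen; one five-membered non-aromatic ring of carbon only, one five-membered non-aromatic ring with 1 hetero atom), on a carbonyl carbon, so the bicyclic amine is replaced by an open-chain amino alcohol carrying one more donor.

Among the compounds with values here, the steps that bear on this all alter the same amide substituent: no change at the digits printed from compound 1 to compound 3 (within the scatter), a 1.9-fold lower number from compound 2 to compound 3 (0.27 log units; within the scatter) and a 1.9-fold higher number from compound 1 to compound 2 (0.27 log units; within the scatter). None of them moved this assay beyond the scatter, whether a ring was enlarged, shrunk or given a hydroxyl. Within the data shown here, there is no measured example of an open-chain amide, which adds uncertainty, but nothing seen here points to a large shift. Compound 4 is therefore expected to show little change, a 1.6-fold higher number from compound 3 to compound 4 (0.21 log units; within the scatter), with an estimated value of 9000 nM in a range from 3500 nM to 25000 nM.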

Compound 4, half-maximal inhibitory concentration: 7590 nM
Compound 4: middle estimate off by 1.2-fold (0.07 log units), on the high side; the measured number falls inside the stated range.
By their numbers in this assay, from the lowest: compounds 1, 3, 4 and 2 (each within the scatter of the next).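

In this assay, replacing the ring amines with the open-chain (1-(hydroxymethyl)ethyl)amino group gives a 1.4-fold higher number from compound 3 to compound 4 (0.14 log units; within the scatter) and a 1.4-fold higher number from compound 1 to compound 4 (0.14 log units; within the scatter) and a 1.3-fold lower number from compound 2 to compound 4 (0.13 log units; within the scatter) and all three steps stay within the scatter. This extends the earlier picture: on this carbonyl carbon, not only can the ring change in size, it can be absent altogether, and the group entering here, which has one more hydrogen-bond donor than the bicyclic group it replaces, still leaves the number where the ring compounds sit. No supporting measurement is available to explain this insensitivity.

The compounds shown leave open whether any group at this position would move the number beyond the scatter, such as a longer chain, or a chain ending in an amine or a carboxylic acid. From the compounds shown here alone, a plain alkyl chain with no oxygen also remains untested here.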